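This account rests on a few compounds, and the source may have more. Where it says the series, first, only, none or still open, it means among the compounds named here.

The measured compounds:
compound 1, `OC1O[C@H](CO/N=C2\CCc3cc(Sc4cc(F)cc(C5CCOCC5)c4)ccc32)[C@H](O)[C@H](O)[C@H]1O`, > 2500 nM
compound 2, `C/C(=N\OCCSc1nnnn1C)c1ccc(Sc2cc(F)cc(C3CCOCC3)c2)cc1`, 120 nM
compound 3, `CO[C@]1(c2cc(F)cc(Sc3ccc(/C(C)=N/OCC#N)cc3)c2)CCO[C@@H](C)C1`, 40 nM

In a functional assay (blood) for inhibition, with Homo sapiens as the target (on this read-out higher numbers stand for weaker inhibition and lower numbers for stronger inhibition), compound 3 gives 40 nM, the lowest of the two numbers recorded; compound 2 sits at 120 nM, a gap beyond the scatter. For compound 1 the assay returns only a limit, > 2500 nM (the limit of > 2500 nM in this assay, at which 1 of the 3 values shown sits). Compound 4, `CO[C@]1(c2cc(F)cc(Sc3ccc(/C(C)=N/O)cc3)c2)CCO[C@@H](C)C1`, has not yet been measured. It differs from compound 3 in one place: hydrogen in place of cyanomethyl on an oxygen. The cyanomethyl group leaves and only a hydrogen enters. No step of this kind has been measured among these compounds, so the expectation rests on compound 3 alone: a modest weakening, a 2.5-fold higher number from compound 3 to compound 4 (0.40 log units; beyond the scatter), is estimated in this assay. Compound 4 is therefore expected to give about 100 nM, within 30 nM to 400 nM.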

Compound 4, half-maximal inhibitory concentration: 40 nM
The estimate for compound 4 lay 2.5-fold (0.40 log units) above the measured number; the measured number falls inside the stated range.
By their numbers in this assay, from the lowest: compounds 3 and 4 (each within the scatter of the next); then compound 2. At a limit, above all of these: compound 1.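

In this assay, hydrogen in place of cyanomethyl on an oxygen whose other neighbour is a double-bonded nitrogen brings no change at the digits printed from compound 3 to compound 4 (within the scatter). Within the data shown here, the read-out at this position therefore holds with the whole cyanomethyl group gone, something the earlier compounds, with no step among them, could not show. Nothing given here bears on why the number holds. On these data alone, whether an amine, a carboxylic acid or a longer chain on this oxygen would hold it too stays open, as does whether the same change would read alike on the core of compound 2.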